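The source may hold more compounds than are shown below. What is called first, only, known or untested is meant among the compounds shown, and "the series" means these compounds.

Compound 1, `CCCCCCNc1nc(SCc2ccc(C(F)(F)F)cc2)nc2ccccc12`: 24300 nM
Compound 2, `FC(F)(F)c1ccc(CSc2nc(Nc3ccccc3Cl)c3ccccc3n2)cc1`: > 50000 nM

In a functional assay on MCF7 cells (Homo sapiens) for cytotoxicity, read by MTT assay, with a stated time of 72 h (a higher number here means a weaker inhibitor, a lower number a stronger inhibitor), compound 1 gives 24300 nM. For compound 2 this assay reports only a limit, > 50000 nM, and no number. Among the measured compounds shown here, the single measured step, an at least 2.0-fold higher number from compound 1 to compound 2 (0.31 log units; beyond the scatter), runs toward weaker inhibition, and its size is known only as a floor because of the limit of > 50000 nM in this assay, at which 1 of the 2 values shown sits. Compound 2 therefore stands at the weak end of the two values shown.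

Compound 3, `COc1ccc(Nc2nc(SCc3ccc(C(F)(F)F)cc3)nc3ccccc23)c(OC)c1`, differs from compound 2 by 2,4-dimethoxyphenyl in place of 2-chlorophenyl on a nitrogen on an aromatic ring. No measured step compares one aryl group with another on this nitrogen; the only step shown exchanges hexyl for an aryl group, and it leads to the limit. With no evidence that a second aryl group reverses that, compound 3 is expected to remain near the limit, with a number no higher from compound 2 to compound 3 (the limit leaves the size open) amounting to no change beyond the scatter. The estimate for compound 3 in this assay is 50000 nM, between 15000 nM and 150000 nM.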

Compound 3, half-maximal inhibitory concentration: > 50000 nM
Compound 3 was reported as a limit; the forecaster's own chance of this, stated with the estimate: 55%; the middle value sits exactly at the limit.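

In this assay a second aryl group on this nitrogen, 2,4-dimethoxyphenyl, again gives weaker inhibition than hexyl, with an at least 2.0-fold higher number from compound 1 to compound 3 (0.31 log units; beyond the scatter) in place of hexyl. The drop on leaving hexyl is therefore no longer tied to 2-chlorophenyl alone: it appears with both aryl groups shown, and compound 1 remains the only one of the three with a readable number. The step between the two aryl groups cannot be read, and no order between compound 2 and compound 3 can be given, since both are reported only as limits: the limit of > 50000 nM in this assay, at which 2 of the 3 values shown sit.

On these data alone, it remains open whether any aryl group on this nitrogen gives a number within the range of this assay. Also open, as far as these compounds go, is how a shorter or longer alkyl chain, a cyclohexyl group or a benzyl group on the same nitrogen would compare with hexyl.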